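From Compound 3 to Compound 4: One Added Methoxy

The compounds below may be only part of what the source reports. "The series", "measured", "known", "first", "only" and "open" are said of these compounds alone.

Compound 1 `COc1ccc(N(C)c2nc(Cl)nc3c2ncn3C)cc1`: 3400 nM
Compound 2 `COc1ccc(N(C)c2ncnc3c2ncn3Cc2ccc(OC)c(OC)c2)cc1`: 430 nM
Compound 3 `COc1ccc(Cn2cnc3c(N(C)c4ccc(OC)cc4)nc(Cl)nc32)cc1`: 31000 nM

In a functional assay on SH-SY5Y cells (Homo sapiens) for antiproliferative activity, read by MTT assay, with a stated time of 48 h (a higher number here means a weaker inhibitor of growth, a lower number a stronger inhibitor of growth), compound 3 gives 31000 nM, the highest of the three numbers and so the weakest growth inhibitor of the set. Compound 4 `COc1ccc(N(C)c2nc(Cl)nc3c2ncn3Cc2ccc(OC)c(OC)c2)cc1` has not yet been measured. It departs from compound 3 by methoxy in place of hydrogen on an aromatic carbon, which turns 4-methoxyphenyl into 3,4-dimethoxyphenyl.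

Going by the values given here, no measured step shows this change on its own. Among the compounds with values here, the one measured step, a 9.1-fold higher number from compound 1 to compound 3 (0.96 log units; beyond the scatter), is beyond the scatter, but it concerns adding the 4-methoxyphenyl group, not adding a methoxy to it. It shows only that this part of the molecule can move the number in this assay. Compound 2 carries the same 3,4-dimethoxyphenyl group and gives 430 nM, but it also differs from compound 4 in another place, so its value offers only a loose hint of a lower number. A moderate drop is therefore expected, though with little certainty, and the estimate is a 5.2-fold lower number from compound 3 to compound 4 (0.71 log units; beyond the scatter). For compound 4 the expected value is 6000 nM, with an estimated range of 1000 nM to 30000 nM.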

Compound 4, concentration for 50% growth inhibition: 7300 nM
Estimate against measurement, compound 4: 1.2-fold (0.09 log units) below; low and high end bracket the measured number.
By their numbers in this assay, from the lowest: compound 2; then compound 1; then compound 4; then compound 3.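

In this assay, the added methoxy gives a 4.2-fold lower number from compound 3 to compound 4 (0.63 log units; beyond the scatter), the first measured sign that turning 4-methoxyphenyl into 3,4-dimethoxyphenyl lowers the number, although the result comes from a single pair on a chloro-bearing core. The gain does not fully recover what the larger group costs at the saturated chain carbon: a 2.1-fold higher number from compound 1 to compound 4 (0.33 log units; beyond the scatter), so the 3,4-dimethoxyphenyl group still sits on the higher side of the plain hydrogen there, while the other new step, a 17-fold higher number from compound 2 to compound 4 (1.23 log units; beyond the scatter), shows that chloro in place of hydrogen on an aromatic carbon of the shared core weighs more heavily here than the methoxy does. No measurement shown gives a reason for any of these shifts.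

The compounds shown leave open whether a hydroxyl, a fluoro or an ethoxy group at the new ring place would lower the number as the methoxy does. They also leave open whether an amine or a nitrile in place of the chloro would keep the low number of compound 2, and whether the methoxy step would be the same size on a core without chloro.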